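Benzyl Arm: From Methyl to Two Hydroxyls

The source may report more compounds than this note shows. Statements on the series, on what has been measured and on what is new or still open speak of the compounds shown alone.

Three analogues sharing one core have been examined in a functional assay on MCF cells (Homo sapiens) for antiproliferative activity, with a stated time of 72 h; on this read-out lower numbers stand for stronger inhibition and higher numbers for weaker inhibition. Compound 1 `Cc1cccc(CNc2ncnc3c2ncn3[C@@H]2O[C@H](CO)[C@@H](O)[C@H]2O)c1` returns only a limit, > 166000 nM. Compound 2 `Cc1ccc(CNc2ncnc3c2ncn3[C@@H]2O[C@H](CO)[C@@H](O)[C@H]2O)cc1` likewise gives only a limit in this assay, > 166000 nM. Compound 3 `COc1cccc(CNc2ncnc3c2ncn3[C@@H]2O[C@H](CO)[C@@H](O)[C@H]2O)c1OC` also stops at a limit, > 166000 nM. Compound 2 therefore stands at the limit together with the other two, as summarised by the limit of > 166000 nM in this assay, at which 3 of the 3 values shown sit. The next compound, compound 4 `OC[C@H]1O[C@@H](n2cnc3c(NCc4cc(O)cc(O)c4)ncnc32)[C@H](O)[C@@H]1O`, differs from compound 2 in one place: 3,5-dihydroxyphenyl in place of 4-methylphenyl on a saturated chain carbon bound to a nitrogen on an aromatic ring. The measured steps touching this position, a step that the two limits leave unreadable from compound 1 to compound 2 and a step that the two limits leave unreadable from compound 2 to compound 3, are both unreadable in size; all three values stand at the limit given by the limit of > 166000 nM in this assay, at which 3 of the 3 values shown sit. No change at this position has yet moved a compound off the limit, so the expected step that the limit leaves unreadable from compound 2 to compound 4 is none beyond the scatter, with a real chance that compound 4 again reports only a limit. For compound 4 the estimate in this assay is 200000 nM, within 40000 nM to 800000 nM.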

Compound 4, half-maximal inhibitory concentration: > 166000 nM
Compound 4: a limit, no number (the forecaster's own chance of this, stated with the estimate: 80%); the middle value does not contradict the limit.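

Compound 4 also returns only a limit in this assay, > 166000 nM. Its steps from compound 1, compound 2 and compound 3 therefore cannot be read, since all four compounds stand at the same limit: the limit of > 166000 nM in this assay, at which 4 of the 4 values shown sit.

What the compounds shown leave open is how strongly any of the four inhibits in this assay, and whether any of these benzyl changes alters that inhibition.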